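The source may report more compounds than this note shows. Statements on the series, on what has been measured and on what is new or still open speak of the compounds shown alone.

In a functional assay on SW620/5-FU cells (Homo sapiens) for cytotoxicity, read by MTT assay, with a stated time of 48 h, in the presence of a further agent that is not named here (on this read-out lower numbers stand for an effect already at smaller amounts and higher numbers for an effect only at larger amounts of compound), compound 1 `Cc1nn(C)c2nc(NNC(=O)Nc3cc(Cl)nc(Cl)c3)cc(C3CCCCC3)c12` gives 22000 nM as its reading. Compound 2 `Cc1ccc(NC(=O)NNc2cc(-c3ccc(F)cc3)c3cnn(C)c3n2)cc1Nc1nccc(-c2cccnc2)n1` gives 33100 nM within the usual scatter of compound 1. Compound 3 `Cn1ncc2c(-c3ccc(F)cc3)cc(NNC(=O)Nc3cc(F)cc(F)c3)nc21` gives 47400 nM and so stands higher than compound 1, beyond the scatter. Compound 1 therefore sits level with compound 2 and under compound 3.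

Compound 4 `Cc1nn(C)c2nc(NNC(=O)Nc3cc(Cl)nc(Cl)c3)cc(-c3ccc(F)cc3)c12` keeps compound 1 intact except for one place (4-fluorophenyl in place of cyclohexyl on an aromatic carbon): 4-fluorophenyl in place of cyclohexyl on an aromatic carbon. Within the data shown here, no two tested compounds differ in one place only, so no measured step shows what this exchange does. Compound 2 at 33100 nM and compound 3 at 47400 nM both carry 4-fluorophenyl, but they also differ from compound 1 elsewhere, which makes them only a loose guide.

The expected change is a 1.4-fold higher number from compound 1 to compound 4 (0.13 log units; within the scatter) and it leans towards a higher number without clearly leaving the scatter. For compound 4 the estimated value is 30000 nM with an expected range from 14000 nM to 60000 nM once it is tested.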

Compound 4, half-maximal effective concentration: 17400 nM
Compound 4: middle estimate off by 1.7-fold (0.24 log units), on the high side; the measured number falls inside the stated range.
By their numbers in this assay, from the lowest: compounds 4, 1, 2 and 3 (each within the scatter of the next, the first and the last beyond it).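

The exchange now has a direct reading in this assay: with the rest of compound 1 kept intact, 4-fluorophenyl in place of cyclohexyl on an aromatic carbon gives a 1.3-fold lower number from compound 1 to compound 4 (0.10 log units; within the scatter), a step within the scatter. Among these compounds, at this position, then, a six-membered aromatic ring bearing fluorine and a six-membered non-aromatic ring of carbon only cannot be told apart, which the earlier compounds, differing in more than one place, could not show. Nothing available here explains this similarity.

Still open, from the compounds shown here alone, is whether an amine, a carboxylic acid or a longer chain at this position would shift the number beyond the scatter. One step also cannot show whether the exchange would read the same with the rest of the molecule changed.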